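Selenocyanate carbamates: swapping an allyl chain for propyl

The source may report more compounds than this note shows. Statements on the series, on what has been measured and on what is new or still open speak of the compounds shown alone.

Measured so far:
- compound 1, `N#C[Se]c1ccc(NC(=O)OCc2ccc([N+](=O)[O-])cc2)cc1`: 47600 nM
- compound 2, `C=CCOC(=O)Nc1ccc([Se]C#N)cc1`: 50100 nM

In a functional assay on HTB-54 cells (Homo sapiens) for cytotoxicity, read by MTT assay, with a stated time of 72 h (a lower number here means a stronger inhibitor of growth, a higher number a weaker inhibitor of growth), compound 2 gives the higher of the two numbers, but compound 1 sits so close that the two values lie within the scatter and tell no order. Compound 3, `CCCOC(=O)Nc1ccc([Se]C#N)cc1`, is not yet measured. It differs from compound 2 by ethyl in place of vinyl on a saturated chain carbon bound to an oxygen next to a carbonyl group. For the measured compounds named here, with no measured step of this kind to lean on, only a step within the scatter is expected, in no set direction. Compound 3 is therefore estimated at 50000 nM, within 20000 nM to 125000 nM, a step of a 1.0-fold lower number from compound 2 to compound 3 (0.00 log units; within the scatter).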

Compound 3, concentration for total growth inhibition: 51900 nM
Estimate against measurement, compound 3: 1.0-fold (0.02 log units) below, within the range that was stated.
By their numbers in this assay, from the lowest: compounds 1, 2 and 3 (each within the scatter of the next).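

In this assay ethyl in place of vinyl on a saturated chain carbon bound to an oxygen next to a carbonyl group gives a 1.0-fold higher number from compound 2 to compound 3 (0.02 log units; within the scatter) and so makes no readable difference. At this position, then, the double bond of the allyl chain is not needed to keep the number in this range, since the propyl chain does as well. Nothing on hand explains this result.

From the compounds shown here alone, whether a longer chain such as hexyl, or an amine at the end of the chain, would move the number beyond the scatter stays open.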